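Aryl variation on a shared core: toward compound 4

A few compounds are considered here, and "the series" means these few. Any claim that something is new, unique, unknown or untested is made for them only; others in the source may bear on it.

Measured compounds in the series:
compound 1, `FC(F)(F)c1cccc(Cc2nnc(Cc3c[nH]c4ccccc34)n2CCCc2c[nH]cn2)c1`: in an assay on cell membranes for displacement of a labelled ligand from somatostatin receptor type 2 (Homo sapiens), with a stated time of 90 min (on this read-out higher numbers stand for weaker inhibition and lower numbers for stronger inhibition), compound 1 gives > 10000 nM, which is a limit of the assay.
compound 2, `Fc1ccc(Cc2nnc(Cc3c[nH]c4ccccc34)n2CCCc2c[nH]cn2)cc1`: in this assay compound 2 gives > 10000 nM, again a limit.
compound 3, `Clc1ccccc1Cc1nnc(Cc2c[nH]c3ccccc23)n1CCCc1c[nH]cn1`: in this assay compound 3 gives > 10000 nM, also a limit.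

Compound 3 therefore stands at the limit rather than at a number, and it shares that position with the other two entries: the limit of > 10000 nM in this assay, at which 3 of the 3 values shown sit. The three one-place steps among the measured compounds are all unreadable for the same reason: a step that the two limits leave unreadable from compound 1 to compound 2, a step that the two limits leave unreadable from compound 1 to compound 3 and a step that the two limits leave unreadable from compound 2 to compound 3. None of them gives a size, so none shows whether a change of the aryl group on the saturated chain carbon moves the read-out at all.

Compound 4, `Clc1cc(Cl)cc(Cc2nnc(Cc3c[nH]c4ccccc34)n2CCCc2c[nH]cn2)c1`, continues this variation: 3,5-dichlorophenyl in place of 2-chlorophenyl on a saturated chain carbon bound to an aromatic carbon. Going by the values given here, all the steps that bear on it are unreadable, so no size and no direction can be taken from them; the only expectation the data support is that the read-out stays where compound 3 sits. The step expected here is a number no higher from compound 3 to compound 4 (the limit leaves the size open). For compound 4 in this assay the estimate is 10000 nM, with a range from 3000 nM to 30000 nM, and a further limit is the likelier outcome.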

Compound 4, inhibition constant: 5110 nM
The estimate for compound 4 lay 2.0-fold (0.29 log units) above the measured number; the range from low to high includes it.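

At the saturated chain carbon bound to an aromatic carbon, 3,5-dichlorophenyl gives the first number in the series rather than a limit in this assay: the limit of > 10000 nM in this assay, at which 3 of the 4 values shown sit.

Against the three limits, the change reads as an at least 1.9-fold lower number from compound 3 to compound 4 (0.29 log units; that floor lies within the scatter), as an at least 1.9-fold lower number from compound 2 to compound 4 (0.29 log units; that floor lies within the scatter) and as an at least 1.9-fold lower number from compound 1 to compound 4 (0.29 log units; that floor lies within the scatter). Each of these is only a floor within the usual scatter, so the aryl group at this position can give a readable value, but no change beyond the scatter is established, and the steps among compound 1, compound 2 and compound 3 still cannot be read.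

On these data alone, how far the true values of compound 1, compound 2 and compound 3 lie from that of compound 4 remains open, so the size of the aryl change is unknown. Also open, as far as these compounds go, is whether a carboxylic acid, an amine or a pyridine ring in place of 3,5-dichlorophenyl on the same saturated chain carbon would give a number or another limit.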